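The source may report more compounds than this note shows. Statements on the series, on what has been measured and on what is new or still open speak of the compounds shown alone.

Measured so far in an assay on CHO cells for displacement of a labelled ligand from adenosine receptor A1 (Homo sapiens), tested at 10 uM; a higher number here means more inhibition at the concentration tested (going by the name of the read-out), a lower number less inhibition:

- compound 1, `O=C(Nc1ccccc1Cl)Nc1nn(-c2ccccc2)c(=O)c2ccccc12`: 0%
- compound 2, `Nc1nn(-c2ccccc2)c(=O)c2ccccc12`: 24%

Among the compounds with values here, compound 2 gives the higher of the two numbers in this assay; the only other compound, compound 1, sits lower by a margin that exceeds the usual scatter, so the two are genuinely separated on the present data. Within the data shown here, no pair differing in a single place has yet been measured, so no step size is established.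

Compound 3, `O=C(Nc1ccccc1)Nc1nn(-c2ccccc2)c(=O)c2ccccc12`, is the next compound to be tested in this assay. Its change relative to compound 2 is phenylcarbamoyl in place of hydrogen on a nitrogen on an aromatic ring. Compound 3 is, by its structure, much closer to compound 1 than to compound 2, and compound 1 gives the lower value. The step is therefore expected to be downward, beyond the scatter, at about a number 19 percentage points lower from compound 2 to compound 3 (beyond the scatter). Compound 3 is estimated at 5%, with a range from 0% to 20%.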

Compound 3, a percentage reported as inhibition, at one concentration (the size of the read-out at that concentration, not a potency): 44%
The estimate for compound 3 lay 39 percentage points below the measured number; the measured number lies above the stated range.
By their numbers in this assay, from the lowest: compound 1; then compound 2; then compound 3.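

In this assay, phenylcarbamoyl in place of hydrogen on the nitrogen on an aromatic ring brings a modest gain in the number (a number 20 percentage points higher from compound 2 to compound 3 (beyond the scatter)). The added phenyl ring is far more sensitive than that gain suggests: hydrogen in place of chloro on an aromatic carbon gives a large change (a number 44 percentage points higher from compound 1 to compound 3 (beyond the scatter)), so the outcome at this nitrogen depends on the substituent carried by that ring and not only on the phenylcarbamoyl group being present. Nothing available explains either step.

As far as these compounds go, it remains open whether fluoro or methoxy on that aromatic carbon would track with chloro or with hydrogen. Also open, from the compounds shown here alone, is whether acetyl or a longer alkyl chain on the nitrogen would retain the gain seen with phenylcarbamoyl.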